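The source may report more compounds than this note shows. Statements on the series, on what has been measured and on what is new or still open speak of the compounds shown alone.

Measured in a functional assay, with a stated time of 10 min; on this read-out higher numbers stand for weaker inhibition and lower numbers for stronger inhibition:
compound 1 `O=c1cc(/C=C/c2ccc(Cl)cc2)occ1O` gives 1950 nM
compound 2 `CCOc1ccc(/C=C/c2cc(=O)c(O)co2)cc1` gives 4210 nM

For the measured compounds named here, compound 2 has the higher of the two numbers, and compound 1 is its only neighbour. The compound to assess is compound 3 `O=c1cc(/C=C/c2ccc(O)cc2)occ1O`, not yet measured. It differs from compound 2 by hydrogen in place of ethyl on an oxygen on an aromatic ring, with hydrogen in place of ethyl on an oxygen on an aromatic ring, or ethoxy to hydroxy. Going by the values given here, one measured step bears on this: a 2.2-fold higher number from compound 1 to compound 2 (0.33 log units; beyond the scatter), modest and beyond the scatter, with ethoxy in place of chloro on an aromatic carbon. That step involves no hydroxy group, so it offers a guide to size but little guide to direction. In this assay a similar or smaller step is expected, with a tentative lean toward a lower number. The expected step is a 1.7-fold lower number from compound 2 to compound 3 (0.23 log units; within the scatter) and rests on thin evidence. For compound 3 the estimated value is 2500 nM, with an expected range from 800 nM to 7500 nM as its bounds.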

Compound 3, half-maximal inhibitory concentration: 1940 nM
The estimate for compound 3 lay 1.3-fold (0.11 log units) above the measured number; the measured number falls inside the stated range.
By their numbers in this assay, from the lowest: compounds 3 and 1 (each within the scatter of the next); then compound 2.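

In this assay, taking the ethyl off the oxygen on the aromatic ring gives a 2.2-fold lower number from compound 2 to compound 3 (0.34 log units; beyond the scatter), so in this pair the step goes with the ethyl and not with the oxygen, which stays in both compounds. Swapping the chloro group for a hydroxy group gives a 1.0-fold lower number from compound 1 to compound 3 (0.00 log units; within the scatter), so the two groups are not told apart on this read-out, and among the three compounds only the ethoxy group stands apart from the others. No data here account for either step.

Still open, going by these compounds, is whether methoxy would read with hydroxy or with ethoxy, and whether a longer chain on the same oxygen would extend the step. How an amine or a carboxylic acid would read at this place also remains unsettled, as does whether the same steps hold with changes elsewhere on the shared core.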